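Halogen swap on the benzyl ring: chloro to fluoro

The source may hold more compounds than are shown below. What is called first, only, known or untested is meant among the compounds shown, and "the series" means these compounds.

The series keeps one shared core and varies a single group on the benzyl ring. Compound 1 `C/C=C/C(=O)N(Cc1ccc(OC)c(C)c1)c1cc(OC)c(OC)c(OC)c1` gives 23500 nM in a functional assay on HCT-116 cells (Homo sapiens) for inhibition, read by MTT assay, with a stated time of 48 h; a higher number here means a weaker inhibitor, a lower number a stronger inhibitor. Compound 2 `C/C=C/C(=O)N(Cc1ccc(OC)c(Br)c1)c1cc(OC)c(OC)c(OC)c1` gives 2800 nM in this assay, and compound 3 `C/C=C/C(=O)N(Cc1ccc(OC)c(Cl)c1)c1cc(OC)c(OC)c(OC)c1` gives 1420 nM in this assay. Replacing methyl shifts the number strongly: an 8.4-fold lower number from compound 1 to compound 2 (0.92 log units; beyond the scatter) and a 17-fold lower number from compound 1 to compound 3 (1.22 log units; beyond the scatter). Between the two halogens the difference is small, a 2.0-fold lower number from compound 2 to compound 3 (0.29 log units; within the scatter), so compound 3 holds the lowest number of the three but is not separated from compound 2 beyond the scatter; it is separated only from compound 1.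

The next compound, compound 4 `C/C=C/C(=O)N(Cc1ccc(OC)c(F)c1)c1cc(OC)c(OC)c(OC)c1`, differs from compound 3 by fluoro in place of chloro on an aromatic carbon. Going by the values given here, two measured steps bear on it. The bromo-to-chloro step from compound 2 to compound 3 was within the scatter, which argues for a small shift. The methyl-to-chloro step was large, and methyl is not a halogen, so it sets only a loose outer bound. A change among halogens is therefore expected to stay near compound 3, with a slight lean toward a higher number, as a 2.1-fold higher number from compound 3 to compound 4 (0.32 log units; beyond the scatter). The estimate for compound 4 in this assay is 3000 nM, with a range from 1000 nM to 9000 nM.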

Compound 4, half-maximal inhibitory concentration: 1160 nM
For compound 4 the middle estimate is 2.6-fold (0.41 log units) above the measured one; the range from low to high includes it.
By their numbers in this assay, from the lowest: compounds 4, 3 and 2 (each within the scatter of the next, the first and the last beyond it); then compound 1.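

At the aromatic carbon ortho to a methoxy group, going from 3-chloro-4-methoxyphenyl to 3-fluoro-4-methoxyphenyl gives a 1.2-fold lower number from compound 3 to compound 4 (0.09 log units; within the scatter) in this assay, so this exchange between halogens does not separate the two compounds. The halogen set now contains its first pair separated beyond the scatter, a 2.4-fold lower number from compound 2 to compound 4 (0.38 log units; beyond the scatter), a modest step, although compound 3 remains within the scatter of both compound 2 and compound 4, so the three halogen compounds form a shallow run rather than distinct levels. The contrast with the methyl compound also extends to a third halogen, a 20-fold lower number from compound 1 to compound 4 (1.31 log units; beyond the scatter), a large step, and across compounds 2, 3 and 4 every halogen reads well away from methyl, with no halogen in this set going against that pattern.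

Still open, on these data alone, is how hydrogen, a hydroxyl, an amine, a nitrile or a trifluoromethyl at this same position would read against the halogens and methyl, and whether the pattern holds with the other parts of the shared core changed. No measurement here addresses why the halogen compounds read close together or why the methyl compound stands apart.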